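This account rests on a few compounds, and the source may have more. Where it says the series, first, only, none or still open, it means among the compounds named here.

The shared core of this small set carries a methyl group and a hydroxy group and is decorated with two four-membered rings. Compound 1 `Cc1nc(N2CCC2)nc(OC2CCC2)c1O` places an azetidin-1-yl group on one side and a cyclobutyloxy group on the other, and compound 2 `Cc1nc(OC2CCC2)nc(N2CCC2)c1O` carries the same two groups with their places exchanged. In a functional assay on cells (Lymphocyte, Homo sapiens), read by a luciferase reporter and ATP content, with a stated time of 48 h, tested at 5 uM (on this read-out higher numbers stand for a weaker effect at the one concentration tested and lower numbers for a stronger effect), compound 1 gives 98%. In this assay compound 2 gives 99%, a number that sits with that of compound 1 within the usual scatter, so the two cannot be told apart and neither shows much effect at the concentration tested. Compound 3 `Cc1nc(OC2CCC2)nc(OC2CCC2)c1O` follows from compound 2 by a single change: cyclobutyloxy in place of azetidin-1-yl on an aromatic carbon. The new group enters next to the ring nitrogen and ortho to the hydroxy group, so that compound 3 carries two cyclobutyloxy groups. Going by the values given here, no step between measured compounds exists to guide the expectation, and the only number available is that compound 2 gives 99% in this assay. Compound 3 is therefore expected to give 97% in this assay, within a range from 87% to 105%. That amounts to an estimated a number 2 percentage points lower from compound 2 to compound 3 (within the scatter), a step of no size beyond the scatter, in neither direction.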

Compound 3, a percentage reported as activity, at one concentration (the size of the read-out at that concentration, not a potency): 99%
Beside the measured number, compound 3's estimate is 2 percentage points below it; measured number inside the range.
By their numbers in this assay, from the lowest: compounds 1, 2 and 3 (each within the scatter of the next).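

In this assay, cyclobutyloxy in place of azetidin-1-yl gives no change at the digits printed from compound 2 to compound 3 (within the scatter), and the same replacement at the other of the two places gives a number 1 percentage points higher from compound 1 to compound 3 (within the scatter). Where compounds 1 and 2 showed only that the two groups can exchange places without a difference that can be read, these steps add that azetidin-1-yl can be absent altogether, at either place, with every step staying within the scatter. No supporting measurement is available to explain these numbers.

From the compounds shown here alone, whether an amine or a carboxylic acid at either place, or a longer chain such as hexyloxy, would give a step beyond the scatter remains open. Since both new steps lie within the scatter, the compounds shown also do not say whether either place can influence this read-out at all.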